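Swapping a cyclohexyl for phenethyl in a calpain ketoamide

The source may hold more compounds than are shown below. What is called first, only, known or untested is meant among the compounds shown, and "the series" means these compounds.

Two peptide-like ketoamides have been measured in an assay on isolated protein (Oryctolagus cuniculus) for inhibition of Calpain-2 catalytic subunit (Homo sapiens), at pH 8.0; on this read-out higher numbers stand for weaker inhibition and lower numbers for stronger inhibition. Compound 1, `CCOC(=O)C(=O)[C@H](CC)NC(=O)[C@H](CC(C)C)NC(=O)[C@H](CC(C)C)NS(=O)(=O)c1ccc2ccccc2c1`, gives 1400 nM. Compound 2, `CCC(NC(=O)C(CC(C)C)NC(=O)OCc1ccccc1)C(=O)C(=O)NCC1CCCCC1`, gives 44 nM, the lower of the two numbers and therefore the stronger inhibitor, with compound 1 well beyond the usual scatter above it. Compound 3, `CCC(NC(=O)C(CC(C)C)NC(=O)OCc1ccccc1)C(=O)C(=O)NCCCc1ccccc1`, has not yet been measured. It differs from compound 2 only at the far end of the amide chain: phenethyl in place of cyclohexyl on a saturated chain carbon bound to an amide-type nitrogen. For the measured compounds named here, with no measured pair showing this kind of change, there is nothing on hand to set its size. The expectation is that the step from compound 2 to compound 3 stays inside the scatter, so a 1.1-fold higher number from compound 2 to compound 3 (0.06 log units; within the scatter) is expected to be no real change. Compound 3 is therefore estimated at 50 nM in this assay, within a range from 18 nM to 140 nM.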

Compound 3, inhibition constant: 43 nM
Compound 3: middle estimate off by 1.2-fold (0.07 log units), on the high side; the range from low to high includes it.
By their numbers in this assay, from the lowest: compounds 3 and 2 (each within the scatter of the next); then compound 1.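

In this assay, putting phenethyl in place of cyclohexyl on a saturated chain carbon bound to an amide-type nitrogen gives a 1.0-fold lower number from compound 2 to compound 3 (0.01 log units; within the scatter), so compound 2 and compound 3 cannot be told apart. For this pair, then, a six-membered non-aromatic ring of carbon only can be exchanged for a six-membered aromatic ring of carbon only, on a longer chain, with no real change in the read-out. Nothing on hand explains why the number holds steady across this swap.

Both groups end in a carbon ring, so these compounds leave open what an amine, a carboxylic acid or a plain unbranched hexyl chain would do at this end of the molecule. Compound 1 differs from both in more than one place, so it says nothing about this position.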